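Swapping a Chain for a Chlorinated Ring

This account rests on a few compounds, and the source may have more. Where it says the series, first, only, none or still open, it means among the compounds named here.

Measured so far:
compound 1 `COC(=O)/C=C/c1cccc(N(Cc2ccc(-c3ccc(OC)cc3)cc2)C(=O)C2CCCCC2)c1` with 89 nM
compound 2 `COC/C=C/c1ccc(CN(C(=O)C2CCCCC2)c2cccc(/C=C/C(=O)OC)c2)cc1` with 233 nM

In an assay on isolated protein with Bile acid receptor (Homo sapiens) as the target (a higher number here means that more compound is needed for the effect, a lower number that less compound is needed), compound 1 gives 89 nM, while compound 2 gives 233 nM. Among the compounds with values here, compound 2 thus stands highest of the two numbers, the single step separating them being a 2.6-fold higher number from compound 1 to compound 2 (0.42 log units; beyond the scatter). That step is the only one measured here, and it bears directly on the new compound.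

Compound 3 `COC(=O)/C=C/c1cccc(N(Cc2ccc(-c3cc(Cl)ccc3OC)cc2)C(=O)C2CCCCC2)c1` differs from compound 2 in one place: 5-chloro-2-methoxyphenyl in place of 3-methoxyprop-1-en-1-yl on an aromatic carbon. In effect this undoes the earlier change partway, since an aromatic ring returns to the position where compound 1 carried one, now bearing a chlorine and a methoxy group. Given that the step from compound 1 to compound 2 raised the number modestly, the reverse direction is expected for compound 3: a modest fall, a 2.1-fold lower number from compound 2 to compound 3 (0.33 log units; beyond the scatter), landing near compound 1. The estimate for compound 3 is 110 nM, with a range from 40 nM to 300 nM.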

Compound 3, half-maximal effective concentration: 233 nM
Estimate against measurement, compound 3: 2.1-fold (0.33 log units) below, and the stated range covers the measured number.
By their numbers in this assay, from the lowest: compound 1; then compounds 2 and 3 (each within the scatter of the next).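

In this assay there is no change at the digits printed from compound 2 to compound 3 (within the scatter), so at this place, on an aromatic carbon para to a large group, 5-chloro-2-methoxyphenyl and the open chain 3-methoxyprop-1-en-1-yl cannot be told apart, even though one is a ring and the other is not. Putting an aromatic ring back is also not enough to return to the number of compound 1: there is a 2.6-fold higher number from compound 1 to compound 3 (0.42 log units; beyond the scatter), so what the ring carries counts here, not just the presence of a ring. No supporting measurement is available to explain either result.

The 5-chloro-2-methoxyphenyl ring differs from 4-methoxyphenyl in both its chlorine and the placing of its methoxy group, and these compounds do not separate the two. Going by these compounds, how a phenyl ring bearing an amine or a carboxylic acid would read at this place also remains open.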